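Thiocyanate for amide on a fluoroindole chain

The source may hold more compounds than are shown below. What is called first, only, known or untested is meant among the compounds shown, and "the series" means these compounds.

Measured so far:
compound 1 `NC(=O)CCCCc1c[nH]c2ccc(F)cc12` — 43 nM
compound 2 `NCCCc1c[nH]c2c(F)cccc12` — 26 nM
compound 3 `NCCCc1c[nH]c2ccc(C(=O)O)cc12` — "not active" (no number reported)

The three compounds share a core and were all tested in an assay on isolated protein for inhibition of Myeloperoxidase (Homo sapiens), read by ELISA, with a stated time of 5 min; on this read-out higher numbers stand for weaker inhibition and lower numbers for stronger inhibition. Compound 1 gives 43 nM, and compound 2 gives 26 nM; the two numbers lie within the usual scatter of one another, so neither can be called the stronger inhibitor. Compound 3 returned no number in this assay and was reported as not active, so it gives no anchor for the size of any step.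

The piece now turns to compound 4 `N#CSCCCc1c[nH]c2ccc(F)cc12`, which has not yet been measured in this assay. It differs from compound 1 in one place:

cyanosulfanyl in place of carbamoylmethyl on a saturated chain carbon, three bonds along the chain from an aromatic carbon

Within the data shown here, no measured pair in this set shares that change, so its effect cannot be read off the data in hand. Since compound 1 and compound 2 sit close together and the only clearly different result, compound 3, carries a change of another kind, the expected step from compound 1 to compound 4 is put at a 1.4-fold lower number from compound 1 to compound 4 (0.16 log units; within the scatter), a shift not clearly beyond the scatter. For compound 4 the expected value in this assay is 30 nM, with a range from 8 nM to 120 nM.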

Compound 4, half-maximal inhibitory concentration: 23 nM
For compound 4 the middle estimate is 1.3-fold (0.12 log units) above the measured one, within the range that was stated.
By their numbers in this assay, from the lowest: compounds 4, 2 and 1 (each within the scatter of the next).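

Among these compounds, replacing carbamoylmethyl with cyanosulfanyl on a saturated chain carbon, three bonds along the chain from an aromatic carbon, gives a 1.9-fold lower number from compound 1 to compound 4 (0.27 log units; within the scatter) in this assay and provides the first reading of a change in one place, which the earlier compounds did not offer. The step shows that this position accepts the exchange without a shift that can be told from the scatter, even though the entering group has 0 hydrogen-bond donors and the leaving group has 1, and it replaces a double bond with a triple bond outside aromatic rings. So within this pair, the amide of compound 1 is not needed for inhibition in this range, and nothing measured here explains why the two groups read alike.

The compounds shown leave open whether the sulfur or the nitrile of cyanosulfanyl matters more, a question that a methyl thioether or a plain nitrile at the same place could separate. On these data alone, it also remains open whether the exchange would read the same way on a longer chain.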